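Methoxy to hydroxy on the shared core of compound 3

A few compounds are considered here, and "the series" means these few. Any claim that something is new, unique, unknown or untested is made for them only; others in the source may bear on it.

Three compounds share one core. In a functional assay on SK-OV-3 cells (Homo sapiens) for inhibition, read by sulforhodamine B assay, with a stated time of 48 h (a higher number here means a weaker inhibitor of growth, a lower number a stronger inhibitor of growth), compound 1 `COc1cc(C)cc(-c2nn(CC#N)cc2-c2ccc(-c3cccc(C(C)=O)c3)nc2)c1` gives 3130 nM, compound 2 `Cc1cc(O)cc(-c2nn(CC#N)cc2-c2ccnc(-c3ccc(Oc4ccccc4)cc3)c2)c1` gives 1200 nM, and compound 3 `COc1cc(C)cc(-c2nn(CC#N)cc2-c2ccnc(-c3ccc(N(C)C)cc3)c2)c1` gives 304 nM, the lowest of the three numbers, with compound 2 nearest and compound 1 furthest, both beyond the scatter. Compound 4 `Cc1cc(O)cc(-c2nn(CC#N)cc2-c2ccnc(-c3ccc(N(C)C)cc3)c2)c1` has not been measured. The change from compound 3 is hydrogen in place of methyl on an oxygen on an aromatic ring. For the measured compounds named here, no measured pair shows this change alone, so its size is unknown. A step of about the scatter in either direction is expected, with a slight lean toward a higher number. Compound 4 is therefore estimated at 450 nM, between 150 nM and 1500 nM, a step of a 1.5-fold higher number from compound 3 to compound 4 (0.17 log units; within the scatter).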

Compound 4, concentration for 50% growth inhibition: 2850 nM
For compound 4 the middle estimate is 6.3-fold (0.80 log units) below the measured one; the measured number lies above the stated range.
By their numbers in this assay, from the lowest: compound 3; then compound 2; then compounds 4 and 1 (each within the scatter of the next).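

Replacing methoxy with hydroxy gives a 9.4-fold higher number from compound 3 to compound 4 (0.97 log units; beyond the scatter) in this assay and this first reading of that change alone shows that, with dimethylamino held fixed, growth inhibition depends strongly on the methyl on this oxygen. With hydroxy held fixed, dimethylamino in place of phenoxy gives a 2.4-fold higher number from compound 2 to compound 4 (0.38 log units; beyond the scatter) and so the far end of the molecule also shifts the number, though by a smaller step. Nothing at hand explains either step.

The compounds shown leave open whether the methoxy to hydroxy step keeps its size when phenoxy replaces dimethylamino. They also leave open how an ethoxy group or an amine would compare on this aromatic ring.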